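The source may hold more compounds than are shown below. What is called first, only, known or untested is meant among the compounds shown, and "the series" means these compounds.

Compound 1 `O=c1cc(-n2cc(CNc3ccccc3)nn2)c2cc(Br)ccc2o1` gives > 50000 nM in a functional assay on MCF7 cells (Homo sapiens) for antiproliferative activity, read by MTT assay, with a stated time of 48 h; on this read-out higher numbers stand for weaker inhibition and lower numbers for stronger inhibition.
Compound 2 `O=c1cc(-n2cc(COc3ccc(Br)cc3)nn2)c2cc(Br)ccc2o1` gives 1920 nM in this assay.
Compound 3 `O=c1cc(-n2cc(COc3ccccc3)nn2)c2cc(O)ccc2o1` gives > 50000 nM in this assay.

Compound 3 sits at the limit of the limit of > 50000 nM in this assay, at which 2 of the 3 values shown sit, and has no number of its own. Compound 4 `O=c1cc(-n2cc(COc3ccc(F)cc3)nn2)c2cc(O)ccc2o1` differs from it by fluoro in place of hydrogen on an aromatic carbon. Within the data shown here, the only measured step, an at least 26-fold lower number from compound 1 to compound 2 (1.41 log units; beyond the scatter), puts a bromo on the same ring but changes the linking atom at the same time, so it bears on the present step only loosely. A single fluoro on that ring is therefore expected to move the number little, if at all beyond the scatter: the estimated step of an at least 1.2-fold lower number from compound 3 to compound 4 (0.09 log units; that floor lies within the scatter) is small. Compound 4 is expected to give about 40000 nM, with a likely range from 8000 nM to 150000 nM.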

Compound 4, half-maximal inhibitory concentration: 4620 nM
Compound 4: the middle estimate sits 8.7-fold (0.94 log units) above what was measured; the whole stated range lies above it.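

Changing phenoxy to 4-fluorophenoxy is enough to give a measurable number in this assay: an at least 10-fold lower number from compound 3 to compound 4 (1.03 log units; beyond the scatter). Among these compounds, compounds 1 and 2 differ in both the linking atom and the ring substituent, whereas here one fluoro on an aromatic carbon, para to a large group, is the only change. The size of this step is only a floor, as compound 3 has only a limit: the limit of > 50000 nM in this assay, at which 2 of the 4 values shown sit.

On these data alone, it remains open whether chloro, methoxy or an amine in the same place would give a similar step. As far as these compounds go, it is also open whether fluoro would do so on the bromo-bearing core of compound 2.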